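The source may hold more compounds than are shown below. What is called first, only, known or untested is meant among the compounds shown, and "the series" means these compounds.

Working notes on the selenium series. Compound 1 `CCCCCCOC(=O)Nc1ccc([Se][Se]c2ccc(NC(=O)OCCCCCC)cc2)cc1` is the symmetric diselenide carrying two hexyl carbamates; compound 2 `N#C[Se]c1ccc(NC(=O)Oc2ccc(F)cc2)cc1` is the selenocyanate carrying a 4-fluorophenyl carbamate. In an ADME assay on 184B5 cells (Homo sapiens) for cytotoxicity, read by MTT assay, with a stated time of 72 h (a lower number here means a stronger inhibitor of growth, a higher number a weaker inhibitor of growth), compound 1 gives 9800 nM, and in the same assay compound 2 gives 29500 nM. Within the data shown here, of the two numbers so far, compound 2 gives the higher one, and its gap to compound 1 lies beyond the scatter; no single-point step connects these two structures, so only the two values themselves are compared here.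

Compound 3 `N#C[Se]c1ccc(NC(=O)Oc2ccc(Cl)cc2)cc1` follows from compound 2 by the change (chloro in place of fluoro on an aromatic carbon), a one-atom swap of halogen on the carbamate aryl group. Nothing measured in this set speaks to such a swap. For compound 3 the expectation is a step from compound 2 that stays within the scatter, the estimated value being 25000 nM in this assay, with a range from 10000 nM to 60000 nM, i.e. an expected step of a 1.2-fold lower number from compound 2 to compound 3 (0.07 log units; within the scatter).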

Compound 3, concentration for total growth inhibition: 19900 nM
Estimate against measurement, compound 3: 1.3-fold (0.10 log units) above; measured number inside the range.
By their numbers in this assay, from the lowest: compound 1; then compounds 3 and 2 (each within the scatter of the next).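

Among these compounds, the step of a 1.5-fold lower number from compound 2 to compound 3 (0.17 log units; within the scatter) is the first single-point comparison, and it gives a direct reading for this position in this assay. With chloro in place of fluoro on an aromatic carbon, para to a large group, the selenocyanate pair stays within the scatter, so this halogen swap does not separate compound 2 from compound 3. No accompanying data bear on this result.

Going by these compounds, whether a non-halogen substituent in the same place, such as a methoxy group, an amine or a carboxylic acid, would give a step beyond the scatter stays open. Also open, on these data alone, is how the selenocyanate would read with a hexyl chain on the carbamate in place of the halogenated aryl group, which would set that group and the selenium function apart.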